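The compounds below may be only part of what the source reports. "The series", "measured", "known", "first", "only" and "open" are said of these compounds alone.

Going by the values given here, compound 3 `Cc1ccc(-c2ccccc2NCC2=NCCN2)o1` is the only one of the three compounds for which a functional assay for activation of Alpha-1B adrenergic receptor (Homo sapiens), read by calcium flux (on this read-out lower numbers stand for an effect already at smaller amounts and higher numbers for an effect only at larger amounts of compound), reports a number: in this assay compound 3 gives 46.8 nM. Compound 1 `Cc1ncc(-c2ccccc2NCC2=NCCN2)o1` reaches only a limit of the assay, < 5020 nM. Compound 2 `Cc1nc(-c2ccccc2NCC2=NCCN2)co1` likewise reaches only a limit, < 5020 nM. The steps a step that the limit leaves unreadable from compound 1 to compound 3 and a step that the limit leaves unreadable from compound 2 to compound 3 cannot be sized, and a step that the two limits leave unreadable from compound 1 to compound 2 cannot be sized either, since (the limit of < 5020 nM in this assay, at which 2 of the 3 values shown sit). Compound 4 `CC/C(=N/OC)c1ccccc1NCC1=NCCN1` differs from compound 3 by a group of 6 heavy atoms (4 carbon, 1 nitrogen, 1 oxygen; no ring) in place of a group of 6 heavy atoms (5 carbon, 1 oxygen; one five-membered aromatic ring with 1 hetero atom), on an aromatic carbon. Among the compounds with values here, none of the measured steps exchanges the five-membered aromatic ring for an open chain, so no measured step bears on this change and its size is open. Compound 4 is estimated at 500 nM, between 80 nM and 3000 nM. The expected step of an 11-fold higher number from compound 3 to compound 4 (1.03 log units; beyond the scatter) is toward a weaker effect.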

Compound 4, half-maximal effective concentration: < 5020 nM
Compound 4: no number, only a limit (the forecaster's own chance of this, stated with the estimate: 25%); the middle value is on the limit's open side.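

In this assay compound 4 reaches only the limit < 5020 nM and no step to it from compound 1, compound 2 or compound 3 can be read: the limit of < 5020 nM in this assay, at which 3 of the 4 values shown sit.

The compounds shown leave open how far the open-chain group of compound 4 and the methyl-oxazolyl groups of compound 1 and compound 2 actually lie from compound 3.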